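The source may hold more compounds than are shown below. What is called first, only, known or untested is meant among the compounds shown, and "the series" means these compounds.

In a functional assay on DU-145 cells (Homo sapiens) for inhibition, read by trypan blue exclusion, with a stated time of 72 h (a higher number here means a weaker inhibitor, a lower number a stronger inhibitor), compound 3 `Cn1c(=O)c(S(=O)(=O)c2ccccc2)cc2cnc(Nc3ccc4cc[nH]c4c3)nc21` gives 10000 nM. Compound 1 `Cn1c(=O)c(S(=O)(=O)c2ccc(F)cc2)cc2cnc(Nc3ccc4cc[nH]c4c3)nc21` gives 10000 nM, the same number at the digits reported. Compound 2 `Cc1ccc(S(=O)(=O)c2cc3cnc(Nc4cnc5c(c4)CC(=O)N5)nc3n(C)c2=O)cc1` gives 15000 nM, still within the usual scatter of compound 3, so no ranking can be read from these three results. Compound 4 `Cc1ccc(S(=O)(=O)c2cc3cnc(Nc4ccc5cc[nH]c5c4)nc3n(C)c2=O)cc1` has not yet been measured and differs from compound 3 in one place: methyl in place of hydrogen on an aromatic carbon. Put another way, phenylsulfonyl becomes (4-methylphenyl)sulfonyl. Among the compounds with values here, only one measured step involves a swap on this ring: no change at the digits printed from compound 1 to compound 3 (within the scatter), with hydrogen in place of fluoro. A single step with a different group is thin evidence, but it gives no reason to expect a real shift in this assay. Compound 2 already carries (4-methylphenyl)sulfonyl and gives 15000 nM, although it differs elsewhere too. The estimated change is no change at the digits printed from compound 3 to compound 4 (within the scatter), which would lie within the scatter. Compound 4 is expected at 10000 nM, with an estimated range of 4000 nM to 20000 nM.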

Compound 4, half-maximal inhibitory concentration: 15000 nM
Beside the measured number, compound 4's estimate is 1.5-fold (0.18 log units) below it, and the stated range covers the measured number.
By their numbers in this assay, from the lowest: compounds 1, 3, 2 and 4 (each within the scatter of the next).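

In this assay, adding the methyl gives a 1.5-fold higher number from compound 3 to compound 4 (0.18 log units; within the scatter), and methyl in place of fluoro gives a 1.5-fold higher number from compound 1 to compound 4 (0.18 log units; within the scatter), so hydrogen, fluoro and methyl on this ring cannot be told apart. With (4-methylphenyl)sulfonyl held fixed, exchanging the group on the nitrogen gives no change at the digits printed from compound 2 to compound 4 (within the scatter), so this second kind of change also stays within the scatter. Nothing available explains these results.

From the compounds shown here alone, only small groups have been seen at this ring position, and it remains open whether any group placed there can move the number beyond the scatter. An amine, a carboxylic acid or a longer chain in place of the methyl would test this, and each could be compared directly with compound 3.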